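Isopropyl in Place of Aminomethyl on the Glycinamide Carbonyl

This account rests on a few compounds, and the source may have more. Where it says the series, first, only, none or still open, it means among the compounds named here.

Measured compounds in a functional assay on the whole organism with Mus musculus as the target, in the rotarod test; on this read-out lower numbers stand for an effect already at smaller amounts and higher numbers for an effect only at larger amounts of compound:
Compound 1 `CN1CCN(CC(=O)NCC(=O)N(C)c2ccc(Cl)cc2C(=O)c2ccccc2Cl)CC1`, for which this assay gives only the limit > 100 mg/kg.
Compound 2 `CCC(=O)NCC(=O)N(C)c1ccc(Cl)cc1C(=O)c1ccccc1Cl`, compound 2 giving 36 mg/kg.
Compound 3 `CN(C(=O)CNC(=O)CN)c1ccc(Cl)cc1C(=O)c1ccccc1Cl`, compound 3 giving 27.7 mg/kg.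

Among the two numbers, compound 3 sits with compound 2 within the scatter of each other, the difference between them being a 1.3-fold lower number from compound 2 to compound 3 (0.11 log units; within the scatter). Compound 1 stands apart at the limit of > 100 mg/kg in this assay, at which 1 of the 3 values shown sits, and the steps away from it are an at least 2.7-fold lower number from compound 1 to compound 2 (0.44 log units; beyond the scatter) and an at least 3.6-fold lower number from compound 1 to compound 3 (0.55 log units; beyond the scatter).

Compound 4 `CC(C)C(=O)NCC(=O)N(C)c1ccc(Cl)cc1C(=O)c1ccccc1Cl` differs from compound 3 by isopropyl in place of aminomethyl on a carbonyl carbon. For the measured compounds named here, the step that bears on this change is the one from compound 2 to compound 3, where amino in place of methyl gave only a 1.3-fold lower number from compound 2 to compound 3 (0.11 log units; within the scatter). An exchange at the same carbonyl carbon between an aminomethyl and a small carbon group is therefore expected to move the number by no more than the scatter in either direction. The step from compound 3 to compound 4 in this assay is estimated at a 1.3-fold higher number from compound 3 to compound 4 (0.10 log units; within the scatter). For compound 4 the expected value in this assay is 35 mg/kg, with a range from 15 mg/kg to 80 mg/kg.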

Compound 4, dose for half-maximal effect: > 100 mg/kg
Compound 4 ended at the assay's limit; the forecaster's own chance of this, stated with the estimate: 8%; at least 2.8-fold (0.45 log units) between middle value and limit.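

In this assay, isopropyl in place of aminomethyl on the carbonyl carbon gives an at least 3.6-fold higher number from compound 3 to compound 4 (0.55 log units; beyond the scatter), so this position does tolerate some changes but not every small carbon group. The smaller change alone, methyl in place of hydrogen on the saturated chain carbon bound to the carbonyl carbon, already gives an at least 2.7-fold higher number from compound 2 to compound 4 (0.44 log units; beyond the scatter), so the shift does not depend on losing the amino group. The step between compound 1 and compound 4 cannot be read, since both stand at a limit of the assay: the limit of > 100 mg/kg in this assay, at which 2 of the 4 values shown sit.

Going by these compounds, it remains open whether a longer chain such as n-propyl, or a ring such as cyclopropyl, on this carbonyl carbon would behave like compound 2 or like compound 4. Also open, on these data alone, is whether dimethylaminomethyl would stay close to compound 3.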